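A few compounds are considered here, and "the series" means these few. Any claim that something is new, unique, unknown or untested is made for them only; others in the source may bear on it.

Working notes on the series. All three measured compounds share the core of compound 1 `COc1cc(-c2cc(/C=C/C(=O)c3ccc(N)cc3)[nH]n2)cc(OC)c1OC` and were read in a functional assay on NCI-H460 cells (Homo sapiens) for cytotoxicity, read by sulforhodamine B assay, with a stated time of 48 h, tested at 0.1 uM (a lower number here means a stronger effect, a higher number a weaker effect of the compound at the concentration tested), where compound 1 gives 102%. Compound 2 `COc1ccc(-c2cc(/C=C/C(=O)c3ccc(OC)c(OC)c3)[nH]n2)cc1` gives 101% in this assay, and compound 3 `COc1cc(-c2cc(/C=C/C(=O)c3ccc(Cl)c(Cl)c3)[nH]n2)cc(OC)c1OC` gives 105%. Compound 1 stands second highest of the three numbers; its nearest neighbour is compound 2 and its furthest is compound 3, both within the scatter of it. Going by the values given here, the single computable step, a number 3 percentage points higher from compound 1 to compound 3 (within the scatter), also lies within the scatter.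

Compound 4 `COc1ccc(-c2cc(/C=C/C(=O)c3ccc(N)cc3)[nH]n2)cc1OC` is not yet measured. It differs from compound 1 by hydrogen in place of methoxy on an aromatic carbon. Among the compounds with values here, no measured step touches this ring, so the step from compound 1 to compound 3 bears only indirectly: exchanging a group on the carbonyl side left the read-out where it was. With all three numbers within the scatter of one another, no shift beyond it is indicated, and compound 4 is expected to give 101%, between 91% and 111%. The expected step is a number 1 percentage points lower from compound 1 to compound 4 (within the scatter), nothing beyond the scatter.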

Compound 4, a percentage reported as activity, at one concentration (the size of the read-out at that concentration, not a potency): 100%
For compound 4 the middle estimate is 1 percentage points above the measured one; measured number inside the range.
By their numbers in this assay, from the lowest: compounds 4, 2, 1 and 3 (each within the scatter of the next).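

In this assay, going by these compounds alone, hydrogen in place of methoxy on an aromatic carbon, ortho to a methoxy group and meta to a large group, gives a number 2 percentage points lower from compound 1 to compound 4 (within the scatter) and is the first measured step at this position. At this concentration, then, the read-out does not separate the compound carrying this methoxy from the one carrying hydrogen, on the background of compound 1. No measurement given here offers an explanation for this result.

Going by these compounds, whether a hydroxy group, an ethoxy group or a fluorine atom on this aromatic carbon would give a number beyond the scatter from compound 1 remains open. Within the data shown here, also open is whether the methoxy-to-hydrogen change would matter at a higher concentration, where the read-out might move away from that of the series so far.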